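The source may report more compounds than this note shows. Statements on the series, on what has been measured and on what is new or still open speak of the compounds shown alone.

Compounds measured so far:
compound 1 `CCOC(=O)C12C(=O)OCC=C1COC2c1ccccc1F` with 22100 nM
compound 2 `CCOC(=O)C12C(=O)OCC=C1COC2c1ccc(Cl)c(Cl)c1` with 72400 nM

Both compounds were tested in a functional assay on HeLa cells (Homo sapiens) for cytotoxicity, read by MTT assay; on this read-out lower numbers stand for stronger inhibition and higher numbers for weaker inhibition. Compound 1 gives 22100 nM in this assay, the lowest of the two numbers shown. Compound 2 gives 72400 nM in this assay, a number that stands well apart from that of compound 1, beyond the usual scatter of the measurement. Going by the values given here, no step between these two compounds is set out here, so nothing more than the two numbers themselves is said of that pair.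

The step now followed leads from compound 1 to compound 3 `CCOC(=O)C12C(=O)OCC=C1COC2c1cccs1`, which has not yet been measured in this assay. The change is thiophen-2-yl in place of 2-fluorophenyl on a saturated ring carbon. Among the compounds with values here, for this change no comparable step among the measured compounds exists, so the expectation rests only on the two numbers available. Compound 3 is expected to stay in the same weak range as compound 1, with a step of a 1.4-fold higher number from compound 1 to compound 3 (0.13 log units; within the scatter), which is not expected to reach beyond the scatter. Compound 3 is therefore estimated at 30000 nM, within a range from 10000 nM to 90000 nM.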

Compound 3, half-maximal inhibitory concentration: 30400 nM
Estimate against measurement, compound 3: 1.0-fold (0.01 log units) below; the range from low to high includes it.
By their numbers in this assay, from the lowest: compounds 1 and 3 (each within the scatter of the next); then compound 2.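

In this assay, going by these compounds alone, putting thiophen-2-yl in place of 2-fluorophenyl on the saturated ring carbon gives a 1.4-fold higher number from compound 1 to compound 3 (0.14 log units; within the scatter) and provides the first comparison at this position, since compound 1 and compound 2 had no step linking them. The read-out does not separate a six-membered aromatic ring of carbon only from a five-membered aromatic ring with 1 hetero atom at this carbon, so in this pair the exchange of one aromatic ring for the other, with fluorine leaving and sulfur entering, leaves the number within the scatter. No measurement of any property of these groups accompanies the result, and nothing therefore accounts for it.

The compounds shown leave open whether a group other than an aromatic ring at this carbon, such as a cyclohexyl group, an amine or a carboxylic acid, would move the number away from those of compound 1 and compound 3. They also leave open what replacing the ethoxycarbonyl group, for instance with a primary amide, would do on the same core.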